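The compounds below may be only part of what the source reports. "The series", "measured", "known", "first", "only" and "open" are said of these compounds alone.

Working notes on the sulfonamide series.

Three analogues share one core and differ only in the group on the sulfonyl sulfur. Compound 1 `O=C(O)CCC/C=C\C[C@H]1[C@@H]2CCC(C2)[C@@H]1NS(=O)(=O)c1ccc([N+](=O)[O-])cc1` gives 1400 nM in a functional assay (plasma) for inhibition, with Oryctolagus cuniculus as the target; on this read-out lower numbers stand for stronger inhibition and higher numbers for weaker inhibition. Compound 2 `Cc1cccc(S(=O)(=O)N[C@H]2C3CC[C@H](C3)[C@@H]2C/C=C\CCCC(=O)O)c1` gives 1700 nM in this assay; the pair shows a 1.2-fold higher number from compound 1 to compound 2 (0.08 log units; within the scatter). Compound 3 `Cc1ccccc1S(=O)(=O)N[C@H]1C2CC[C@H](C2)[C@@H]1C/C=C\CCCC(=O)O` gives 6200 nM in this assay, the highest of the three numbers: a 4.4-fold higher number from compound 1 to compound 3 (0.65 log units; beyond the scatter) and a 3.6-fold higher number from compound 2 to compound 3 (0.56 log units; beyond the scatter).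

Compound 4 `O=C(O)CCC/C=C\C[C@H]1[C@@H]2CCC(C2)[C@@H]1NS(=O)(=O)CCCc1ccccc1` is not yet measured. Against compound 3 the change is 3-phenylpropyl in place of 2-methylphenyl on a sulfonyl sulfur. For the measured compounds named here, no measured step bears directly on this change: all three measured steps exchange one aryl group on the sulfonyl sulfur for another aryl group, whereas here a chain carrying the phenyl group replaces the aryl itself. The two steps into compound 3 both run toward a weaker number, so the 2-methylphenyl group that now leaves sits at the weak end of what is known, and removing it is more likely to bring the number back toward compound 1 and compound 2 than to push it further out. Going by these compounds, whether a 3-phenylpropyl group on the sulfonyl sulfur is tolerated at all is unknown.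

Compound 4 is therefore expected to show a 2.1-fold lower number from compound 3 to compound 4 (0.32 log units; beyond the scatter) in this assay, with the estimate held wide. The estimate for compound 4 in this assay is 3000 nM, between 600 nM and 15000 nM.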

Compound 4, half-maximal inhibitory concentration: 14000 nM
Estimate against measurement, compound 4: 4.7-fold (0.67 log units) below; the measured number falls inside the stated range.
By their numbers in this assay, from the lowest: compounds 1 and 2 (each within the scatter of the next); then compound 3; then compound 4.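

Compound 4 is the only compound shown in which a chain, rather than an aryl group, sits on the sulfonyl sulfur, and in this assay this change gives a 2.3-fold higher number from compound 3 to compound 4 (0.35 log units; beyond the scatter) and an 8.2-fold higher number from compound 2 to compound 4 (0.92 log units; beyond the scatter) and a 10-fold higher number from compound 1 to compound 4 (1.00 log units; beyond the scatter) with all three steps beyond the scatter. The position therefore accepts 3-phenylpropyl with measurable inhibition retained, but that group gives the highest number of the four even though it keeps the one six-membered aromatic ring of carbon only, so the ring alone does not fix the number here; this reading rests on compound 4 alone. Nothing available explains why the number rises with this change.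

Going by these compounds, it remains open whether the higher number belongs to the chain as such or to its length, and benzyl or 2-phenylethyl on the sulfonyl sulfur would be the direct comparison, with a plain methyl or butyl group showing what the phenyl ring contributes. Also open, on these data alone, is how an amine or a carboxylic acid at the end of the chain would read in the same assay.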